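The source may report more compounds than this note shows. Statements on the series, on what has been measured and on what is new or still open speak of the compounds shown alone.

Working notes on the series. In a functional assay on A-375 cells (Homo sapiens) for antiproliferative activity, read by MTT assay, with a stated time of 72 h (on this read-out lower numbers stand for stronger inhibition and higher numbers for weaker inhibition), compound 1 `COc1ccc(N2C(=O)COc3ccc(-c4cnc(OC)c(NS(=O)(=O)c5ccc(F)cc5)c4)cc32)cc1` gives 18400 nM. Compound 3 `COc1cccc(N2C(=O)COc3ccc(-c4ccc(O)cc4)cc32)c1` gives 30400 nM in this assay, a value within the scatter of compound 1, so no order between the two is claimed; of the two numbers shown, compound 1 holds the lower one. Compound 2 `O=C1COc2ccc(-c3cnc4ccccc4c3)cc2N1` yields no number in this assay, only a limit, > 40000 nM. One of the three values is thus (the limit of > 40000 nM in this assay, at which 1 of the 3 values shown sits).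

Compound 4 `COc1ncc(-c2ccc3c(c2)N(C2CCCCC2)C(=O)CO3)cc1NS(=O)(=O)c1ccc(F)cc1` is not yet measured; it differs from compound 1 in one place: cyclohexyl in place of 4-methoxyphenyl on an amide-type nitrogen in a ring. For the measured compounds named here, no measured pair spans a change of this kind, so the expected step of a 1.1-fold higher number from compound 1 to compound 4 (0.04 log units; within the scatter) is none beyond the scatter. For compound 4 the estimate in this assay is 20000 nM, with a range from 6000 nM to 60000 nM.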

Compound 4, half-maximal inhibitory concentration: > 40000 nM
Compound 4: a limit, no number (the forecaster's own chance of this, stated with the estimate: 25%); middle value at least 2.0-fold (0.30 log units) from the limit.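

For the compounds shown here, this is the first measured change at the amide-type nitrogen in a ring: cyclohexyl in place of 4-methoxyphenyl gives an at least 2.1-fold higher number from compound 1 to compound 4 (0.33 log units; beyond the scatter) in this assay. At this position, then, replacing the aromatic ring of carbon only with a non-aromatic one does not leave the read-out within the scatter. The full size of the step stays unknown, since compound 4 gives a limit and not a number: the limit of > 40000 nM in this assay, at which 2 of the 4 values shown sit.

With a single step at this position, no trend across groups can be drawn. From the compounds shown here alone, how a benzyl group or an ethyl chain ending in an amine would read on this nitrogen remains open.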